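The source may hold more compounds than are shown below. What is called first, only, known or untested is meant among the compounds shown, and "the series" means these compounds.

Compound 2, `Cc1cn([C@@H]2O[C@H](CO)[C@@H](CN)[C@H]2O)c(=O)[nH]c1=O`, gives the lower of the two numbers in an assay on isolated protein for inhibition of thymidine kinase, cytosolic (Homo sapiens) (a higher number here means a weaker inhibitor, a lower number a stronger inhibitor), at 110000 nM; compound 1, `Cc1cn([C@@H]2O[C@H](COP(=O)(O)O)[C@@H](CN)[C@H]2O)c(=O)[nH]c1=O`, gives 280000 nM. Among the compounds with values here, the only measured step, a 2.5-fold lower number from compound 1 to compound 2 (0.41 log units; beyond the scatter), concerns the oxygen on a saturated carbon, not the ring. Compound 3, `Cc1cn([C@H]2C[C@H](CN)[C@@H](CO)O2)c(=O)[nH]c1=O`, differs from compound 2 by hydrogen in place of hydroxy on a saturated ring carbon. Within the data shown here, since no measured step touches this ring position, the expectation rests loosely on that single step; a modest move toward a lower number is expected, a 2.8-fold lower number from compound 2 to compound 3 (0.44 log units; beyond the scatter). Compound 3 is therefore estimated at 40000 nM, within 8000 nM to 150000 nM.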

Compound 3, inhibition constant: 220000 nM
Estimate against measurement, compound 3: 5.5-fold (0.74 log units) below; measured number above the stated range.
By their numbers in this assay, from the lowest: compounds 2, 3 and 1 (each within the scatter of the next, the first and the last beyond it).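

Taking the hydroxy off this saturated ring carbon and leaving hydrogen gives a step that lies within the scatter of this assay (a 2.0-fold higher number from compound 2 to compound 3 (0.30 log units; within the scatter)). This is the first look at the ring position, and here the numbers of the two compounds cannot be told apart, so the hydroxy is not shown to matter for this measurement. Nothing available gives a reason for this result.

Going by these compounds, whether a fluorine, a methoxy group or an amine on this ring carbon would move the number stays open. So does the part played by the aminomethyl group on the neighbouring ring atom.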